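Swapping a Chlorinated Benzyl for a Thiophene Methyl

The compounds below may be only part of what the source reports. "The series", "measured", "known", "first", "only" and "open" are said of these compounds alone.

Measured so far:
compound 1, `O=S(=O)(NCc1ccc(F)cc1)c1ccc2c(c1)nc(SCCO)n2Cc1ccccc1`: 600 nM
compound 2, `CCOc1nc2cc(S(=O)(=O)NCc3ccc(F)cc3)ccc2n1Cc1cccc(Cl)c1`: 1900 nM

In an assay on isolated protein for inhibition of Gonadotropin-releasing hormone receptor (Rattus norvegicus) (a higher number here means a weaker inhibitor, a lower number a stronger inhibitor), compound 1 gives 600 nM, and compound 2 gives 1900 nM. Of the two numbers in hand, compound 2 holds the higher one, and its gap to compound 1 lies beyond the usual scatter of repeated measurements, so compound 2 is the weaker inhibitor of the pair.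

Compound 3, `CCOc1nc2cc(S(=O)(=O)NCc3ccc(F)cc3)ccc2n1Cc1ccsc1`, has not yet been measured. It differs from compound 2 in a single place: thiophen-3-yl in place of 3-chlorophenyl on a saturated chain carbon bound to an aromatic nitrogen. The group that enters has fewer heavy atoms than the one that leaves, and it brings a hydrogen-bond acceptor where there was none.

Going by the values given here, no measured pair shows this kind of exchange, so the direction of the step cannot be read from the data. A modest step toward a higher number, possibly within the scatter, is expected. Compound 3 is expected to land near 3000 nM, within a range of 1000 nM to 9000 nM. The expected step is a 1.6-fold higher number from compound 2 to compound 3 (0.20 log units; within the scatter).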

Compound 3, half-maximal inhibitory concentration: 2000 nM
Compound 3: the middle estimate sits 1.5-fold (0.18 log units) above what was measured; the measured number falls inside the stated range.
By their numbers in this assay, from the lowest: compound 1; then compounds 2 and 3 (each within the scatter of the next).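

Across this assay, putting thiophen-3-yl in place of 3-chlorophenyl on a saturated chain carbon bound to an aromatic nitrogen gives a 1.1-fold higher number from compound 2 to compound 3 (0.02 log units; within the scatter), so this measurement does not tell the two compounds apart. Going by these compounds alone, this is the first pair in the set that differs in only one place, and it shows that this position accepts a quite different ring without a change beyond the scatter. A six-membered aromatic ring of carbon only, carrying a chlorine, gives way to a five-membered aromatic ring with 1 hetero atom, the group falls from 7 heavy atoms to 5, and it gains 1 hydrogen-bond acceptor, yet the number stays within the scatter. Nothing in hand bears on why the exchange leaves the result this way.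

On these data alone, it remains open whether this tolerance extends beyond neutral aromatic rings, for example to an amine or a carboxylic acid in the same place, or to a longer chain in place of the single saturated chain carbon. No pair shown changes the ethoxy group alone, so what a methoxy group or an amine would do there is also an open question.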